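Amide variation on the shared core: pyrrolidinyl analogue

This account rests on a few compounds, and the source may have more. Where it says the series, first, only, none or still open, it means among the compounds named here.

Among the measured compounds shown here, compound 1 `CCCN(CCC)C(=O)Cc1c(-c2ccc(OC)cc2)nn2c(CC)cc(CC)nc12` gives 5.57 nM in an assay on C6 cells for displacement of a labelled ligand from Translocator protein (Rattus norvegicus), read by scintillation counting, with a stated time of 2 h (a higher number here means a weaker inhibitor, a lower number a stronger inhibitor), the highest of the two numbers known so far; compound 2 `CCCCCN(CCCCC)C(=O)Cc1c(-c2ccc(OC)cc2)nn2c(CC)cc(CC)nc12` sits lowest at 2.17 nM. Compound 3 `CCc1cc(CC)n2nc(-c3ccc(OC)cc3)c(CC(=O)N3CCCC3)c2n1` carries pyrrolidin-1-yl in place of dipropylamino on a carbonyl carbon. For the measured compounds named here, the only measured step, a 2.6-fold lower number from compound 1 to compound 2 (0.41 log units; beyond the scatter), concerns dipentylamino in place of dipropylamino and so moves to another acyclic amine, whereas compound 3 brings a five-membered non-aromatic ring; no measured step bears directly on this change. The acyclic step is not expected to transfer to a ring, so compound 3 is estimated to give 7.5 nM (range 2.5 nM to 22 nM), an expected step of a 1.3-fold higher number from compound 1 to compound 3 (0.13 log units; within the scatter) that should stay within the scatter.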

Compound 3, inhibition constant: 127 nM
Estimate against measurement, compound 3: 17-fold (1.23 log units) below; measured number above the stated range.
By their numbers in this assay, from the lowest: compound 2; then compound 1; then compound 3.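

In this assay, replacing the acyclic amine on the carbonyl carbon with pyrrolidin-1-yl gives large steps (a 23-fold higher number from compound 1 to compound 3 (1.36 log units; beyond the scatter)) and (a 59-fold higher number from compound 2 to compound 3 (1.77 log units; beyond the scatter)). Both far exceed the step between the two acyclic amines (a 2.6-fold lower number from compound 1 to compound 2 (0.41 log units; beyond the scatter)), so this position tolerates dipropylamino and dipentylamino much better than the ring shown here. No available evidence accounts for the size of these steps.

Pyrrolidin-1-yl differs from dipropylamino in both ring closure and heavy-atom count, so the two changes cannot be separated here. Diethylamino and piperidin-1-yl on the same carbonyl carbon remain open comparisons.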